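The compounds below may be only part of what the source reports. "The series", "measured", "known", "first", "only" and "open" are said of these compounds alone.

Compound 3 `COc1cc2ncnc(Nc3ccc(F)c(Cl)c3)c2cc1NC(=O)N/N=C/c1ccc(C#N)cc1`: 32200 nM
Compound 1 `N#Cc1ccc(/C=N/NC(=O)Nc2cc3c(Nc4ccc(F)c(Cl)c4)ncnc3cc2O[C@H]2CCOC2)cc1`: 29100 nM
Compound 2 `O=C(N/N=C/c1cc(Br)c(O)c(Br)c1)Nc1cc2c(Nc3ccc(F)c(Cl)c3)ncnc2cc1O[C@H]1CCOC1`: 8910 nM

All three were tested in a functional assay on A549 cells (Homo sapiens) for cytotoxicity, read by MTT assay, with a stated time of 72 h; on this read-out higher numbers stand for weaker inhibition and lower numbers for stronger inhibition. Among these numbers compound 3 gives the highest one in this assay; compound 1 lies closest to it, within the scatter, so the two cannot be ranked against each other, while compound 2 lies furthest away, beyond the scatter, and so is the only one that clearly inhibits more strongly than compound 3.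

Compound 4 `COc1cc2ncnc(Nc3ccc(F)c(Cl)c3)c2cc1NC(=O)N/N=C/c1ccc(O)cc1O` is not yet measured. It differs from compound 3 in a single place: 2,4-dihydroxyphenyl in place of 4-cyanophenyl on a carbon with a double bond to nitrogen.

Among the compounds with values here, one measured step bears on this change. The step of a 3.3-fold lower number from compound 1 to compound 2 (0.51 log units; beyond the scatter) replaced the same 4-cyanophenyl with 3,5-dibromo-4-hydroxyphenyl and gave a modest lowering of the number. The step of a 1.1-fold higher number from compound 1 to compound 3 (0.04 log units; within the scatter) shows that methyl in place of oxolan-3-yl made no difference beyond the scatter, so compound 1 and compound 3 are comparable starting points. Within the data shown here, the group entering compound 4, 2,4-dihydroxyphenyl, is not the same as the one in compound 2, so a smaller step in the same direction is expected: a 2.0-fold lower number from compound 3 to compound 4 (0.30 log units; within the scatter) is the expected change. Compound 4 is therefore estimated at 16000 nM, probably between 6000 nM and 40000 nM.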

Compound 4, half-maximal inhibitory concentration: 31400 nM
The estimate for compound 4 lay 2.0-fold (0.29 log units) below the measured number, within the range that was stated.
By their numbers in this assay, from the lowest: compound 2; then compounds 1, 4 and 3 (each within the scatter of the next).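

In this assay, the exchange of 4-cyanophenyl for 2,4-dihydroxyphenyl on a carbon with a double bond to nitrogen gave a 1.0-fold lower number from compound 3 to compound 4 (0.01 log units; within the scatter), so a ring with a nitrile and a ring with two hydroxyl groups cannot be told apart here, even though the hydrogen-bond donors go from none to two. Within the data shown here, the earlier step of a 3.3-fold lower number from compound 1 to compound 2 (0.51 log units; beyond the scatter) was the only lowering of the number so far, and its entering ring, 3,5-dibromo-4-hydroxyphenyl, carries both a hydroxyl and two bromines; the new step shows that hydroxyl groups on this ring do not by themselves bring a lower number, at least in the 2,4-dihydroxyphenyl arrangement with the methyl on the oxygen. No measurement is available that explains why this exchange leaves the number unmoved.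

The compounds shown leave open whether the bromines account for the lowering, which a plain 3,5-dibromophenyl ring would help to settle, and whether 2,4-dihydroxyphenyl would act the same way with oxolan-3-yl on the oxygen. Also open, as far as these compounds go, is how a ring carrying an amine or a carboxylic acid would behave in this place.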